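Ethyl to Cyano on a Fused Bicyclic Agonist Core

The source may hold more compounds than are shown below. What is called first, only, known or untested is meant among the compounds shown, and "the series" means these compounds.

compound 1, `COc1nn(-c2ccccn2)c2cc(-c3ccc(CCC(=O)O)cc3)ccc12`, in a functional assay on cells for agonist activity at Free fatty acid receptor 1 (Mus musculus), read by FLIPR and calcium flux, with a stated time of 5 min (a lower number here means a smaller maximal response, a higher number a larger maximal response), gives 96%
compound 2, `CCc1nn(-c2ccccn2)c2cc(-c3ccc(CCC(=O)O)cc3)ccc12`, in this assay gives 93%

Compound 2 holds the lower of the two numbers, with compound 1 its nearest neighbour, and the step of a number 3 percentage points lower from compound 1 to compound 2 (within the scatter) stays within the scatter. Compound 3, `N#Cc1nn(-c2ccccn2)c2cc(-c3ccc(CCC(=O)O)cc3)ccc12`, carries the change (cyano in place of ethyl on an aromatic carbon). Within the data shown here, only the step of a number 3 percentage points lower from compound 1 to compound 2 (within the scatter) bears on this, and it was flat; no measured step exchanges an ethyl for a cyano, so nothing in the data points to a shift, and the expected step is a number 1 percentage points lower from compound 2 to compound 3 (within the scatter). Compound 3 is therefore estimated at 92%, in the range 75% to 105%.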

Compound 3, largest response reached (reported as efficacy), in percent of the reference or control that the assay uses in the Free fatty acid receptor 1 assay: 124%
Compound 3: middle estimate off by 32 percentage points, on the low side; the whole stated range lies below it.
By their numbers in the Free fatty acid receptor 1 assay, from the lowest: compounds 2 and 1 (each within the scatter of the next); then compound 3.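

The position proved able to move the Free fatty acid receptor 1 assay after all: cyano gives one clear step against ethyl (a number 31 percentage points higher from compound 2 to compound 3 (beyond the scatter)) and another against methoxy (a number 28 percentage points higher from compound 1 to compound 3 (beyond the scatter)), whereas those two groups had stayed within the scatter of each other. In a physicochemical assay for lipophilicity, using the shake flask method, measured as octanol-water partition, with a stated time of 30 min, at pH 7.4 (a higher number here means a more lipophilic compound, a lower number a more polar compound), compound 2 gives 3.3 and compound 3 gives 3 (a number 0.30 log units lower from compound 2 to compound 3 (within the scatter)), so the gain in maximal response came without a shift beyond the scatter in that read-out. Nothing at hand explains the gain. The compounds shown leave open whether it belongs to cyano alone or would also follow a trifluoromethyl, a chlorine or a primary amide on this aromatic carbon.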